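Prenyl Ether Swap on a Hydrazone Cinnamamide

A few compounds are considered here, and "the series" means these few. Any claim that something is new, unique, unknown or untested is made for them only; others in the source may bear on it.

Measured compounds:
- compound 1 `O=C(/C=C/c1ccc(OCC(F)(F)F)cc1)NNC(=O)c1ccncc1`: "not determined" (no result reported)
- compound 2 `CC(C)=CCOc1ccc(/C=C/C(=O)NNC(=O)c2ccncc2)cc1`: 256000 nM
- compound 3 `CCOc1ccc(/C=C/C(=O)N/N=c2/[nH]ncc3ccccc23)cc1`: "not determined" (no result reported)

Compound 3 `CCOc1ccc(/C=C/C(=O)N/N=c2/[nH]ncc3ccccc23)cc1` has no single number in an ADME assay on THP-1 cells (Homo sapiens) for cytotoxicity, read by MTT assay, with a stated time of 72 h; a lower number here means a stronger inhibitor, a higher number a weaker inhibitor; compound 1 likewise reports none. Among the measured compounds shown here, the only number in the set belongs to compound 2, which gives 256000 nM in this assay, a weak effect. So compound 3 stands without a known place, and no step between measured compounds can be stated.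

Compound 4 `CC(C)=CCOc1ccc(/C=C/C(=O)N/N=c2/[nH]ncc3ccccc23)cc1` differs from compound 3 in one spot: 2-methylprop-1-en-1-yl in place of methyl on a saturated chain carbon bound to an oxygen on an aromatic ring. The same exchange, read one bond further out, turns an ethoxy into a (3-methylbut-2-en-1-yl)oxy group, the group that compound 2 also carries on its own core.

The step from compound 3 to compound 4 cannot be sized from the data; no direction beyond the scatter is claimed. Because compound 2 gives 256000 nM in this assay, weak cytotoxicity is expected for compound 4 as well. Compound 4 is estimated at 200000 nM, within 50000 nM to 800000 nM.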

Compound 4, half-maximal inhibitory concentration: 26000 nM
For compound 4 the middle estimate is 7.7-fold (0.89 log units) above the measured one; the measured number lies below the stated range.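

Among the compounds shown here, compound 3 has no single number in this assay, so no step from it to compound 4 can be read. No measurement shown offers an explanation for the result of compound 4.

Going by these compounds, what the exchange of ethoxy for (3-methylbut-2-en-1-yl)oxy does on the shared core stays open.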